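Spiro-lactam in place of benzamide on a fused triazolopyrimidine

This account rests on a few compounds, and the source may have more. Where it says the series, first, only, none or still open, it means among the compounds named here.

Measured compounds:
compound 1, `O=C1CCCN1c1cnc(NCc2c(F)ccc3c2CCO3)n2cnnc12`, 1.3
compound 2, `Fc1ccc2c(c1CNc1ncc(Oc3ccccc3)c3nncn13)CCO2`, 3.5
compound 3, `O=C(Nc1cnc(NCc2c(F)ccc3c2CCO3)n2cnnc12)c1ccccc1`, 3

All three were studied in a physicochemical assay for lipophilicity, using the shake flask method, in phosphate buffer, measured as octanol-water partition, with a stated time of 30 min, at pH 7.4; on this read-out lower numbers stand for lower lipophilicity and higher numbers for higher lipophilicity. Compound 3 sits second highest of the three numbers; its nearest neighbour is compound 2, which lies a number 0.50 log units lower from compound 2 to compound 3 (beyond the scatter) in reverse, and the furthest is compound 1, from which a number 1.70 log units higher from compound 1 to compound 3 (beyond the scatter).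

Compound 4, `O=C1CC2(CC2)CN1c1cnc(NCc2c(F)ccc3c2CCO3)n2cnnc12`, is the next compound to be measured. It differs from compound 3 in one place: a group of 8 heavy atoms (6 carbon, 1 nitrogen, 1 oxygen; one three-membered non-aromatic ring of carbon only, one five-membered non-aromatic ring with 1 hetero atom) in place of a group of 9 heavy atoms (7 carbon, 1 nitrogen, 1 oxygen; one six-membered aromatic ring of carbon only), on an aromatic carbon. The entering group is a lactam of the same kind as the 2-oxopyrrolidin-1-yl of compound 1, carrying an added three-membered non-aromatic ring of carbon only.

Within the data shown here, the steps that bear on this change are those that installed or removed the benzamido and the phenoxy groups. From compound 1 to compound 3 the read-out rose by a number 1.70 log units higher from compound 1 to compound 3 (beyond the scatter); from compound 1 to compound 2 it rose by a number 2.20 log units higher from compound 1 to compound 2 (beyond the scatter); and from compound 2 to compound 3 it fell by a number 0.50 log units lower from compound 2 to compound 3 (beyond the scatter). Because compound 1, with the plain lactam, gives 1.3, compound 4 is expected to fall well below compound 3, though above compound 1. Compound 4 is therefore estimated at 2, with a range of 1.5 to 2.5, which means an expected step of a number 1.00 log units lower from compound 3 to compound 4 (beyond the scatter).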

Compound 4, distribution coefficient: 1.9
For compound 4 the middle estimate is 0.10 log units above the measured one, within the range that was stated.
By their numbers in this assay, from the lowest: compound 1; then compound 4; then compound 3; then compound 2.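

In this assay, the two lactams stay close together compared with the aromatic groups: adding the three-membered ring of carbon only gives a number 0.60 log units higher from compound 1 to compound 4 (beyond the scatter), while replacing the aromatic groups with the new lactam gives a number 1.10 log units lower from compound 3 to compound 4 (beyond the scatter) and a number 1.60 log units lower from compound 2 to compound 4 (beyond the scatter). At this aromatic carbon, para to a large group, the read-out therefore changes with a modification of the lactam itself and not only with an exchange of the lactam for benzamido or phenoxy, and the new group falls between the plain lactam and both aromatic groups. The step away from benzamido also removes a hydrogen-bond donor and exchanges a six-membered aromatic ring for two non-aromatic rings, and nothing available explains the size of any of these steps or assigns it to one of these differences.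

The compounds shown leave open whether the three-membered ring differs in its effect from two methyl groups or an ethyl chain on the same lactam. They also leave open where an amine or a carboxylic acid at this aromatic carbon would fall relative to the four groups compared here.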